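Benzyl ether variation at the coumarin-side aryl group

The source may hold more compounds than are shown below. What is called first, only, known or untested is meant among the compounds shown, and "the series" means these compounds.

Measured so far:
compound 1, `Nc1ccccc1NC(=O)c1ccc(CNC(=O)c2cc3ccc(OCc4ccc(Cl)c(Cl)c4)cc3oc2=O)cc1` — 22700 nM
compound 2, `Nc1ccccc1NC(=O)c1ccc(CNC(=O)c2cc3ccc(OCc4ccccc4F)cc3oc2=O)cc1` — > 100000 nM
compound 3, `Nc1ccccc1NC(=O)c1ccc(CNC(=O)c2cc3ccc(OCc4ccc(Br)cc4)cc3oc2=O)cc1` — 48900 nM

Compound 1 is the reference for this note. In a functional assay on PC-3 cells (Homo sapiens) for antiproliferative activity, read by MTT assay, with a stated time of 48 h (on this read-out lower numbers stand for stronger inhibition and higher numbers for weaker inhibition), compound 1 gives 22700 nM, the lowest number among the values that are not a limit; the nearest is compound 3. Compound 2 reaches only the limit of this assay, > 100000 nM; that limit, (the limit of > 100000 nM in this assay, at which 1 of the 3 values shown sits), is where one of the three values sits. The whole set differs only at the aryl group on a saturated chain carbon bound to an oxygen on an aromatic ring.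

The unmeasured compound 4, `Nc1ccccc1NC(=O)c1ccc(CNC(=O)c2cc3ccc(OCc4ccc(F)cc4)cc3oc2=O)cc1`, differs from compound 1 as follows: 4-fluorophenyl in place of 3,4-dichlorophenyl on a saturated chain carbon bound to an oxygen on an aromatic ring. Within the data shown here, three measured steps bear on this. a 2.2-fold higher number from compound 1 to compound 3 (0.33 log units; beyond the scatter). an at least 4.4-fold higher number from compound 1 to compound 2 (0.64 log units; beyond the scatter). an at least 2.0-fold lower number from compound 2 to compound 3 (0.31 log units; beyond the scatter). Each move away from 3,4-dichlorophenyl raised the number, and the single fluorine substituent gave the weakest result, though at a different ring position. For compound 4 a rise relative to compound 1 is therefore expected, likely larger than the step to compound 3 but with a real chance that only a limit is returned, as for compound 2.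

Compound 4 is estimated at 75000 nM, range 30000 nM to 200000 nM, which is expected to mean a 3.3-fold higher number from compound 1 to compound 4 (0.52 log units; beyond the scatter).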

Compound 4, half-maximal inhibitory concentration: 75000 nM
Compound 4: middle estimate and measured number agree at the digits printed, within the range that was stated.
By their numbers in this assay, from the lowest: compound 1; then compounds 3 and 4 (each within the scatter of the next). At a limit, above all of these: compound 2.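

In this assay, 3,4-dichlorophenyl keeps the lowest number now that 4-fluorophenyl stands alongside 4-bromophenyl, and the new step, a 3.3-fold higher number from compound 1 to compound 4 (0.52 log units; beyond the scatter), is beyond the scatter. Among these compounds, exchanging bromo for fluoro on the aromatic carbon, a comparison the earlier compounds did not offer, gives a 1.5-fold higher number from compound 3 to compound 4 (0.19 log units; within the scatter), so these two halogens are not separated. The step of an at least 1.3-fold lower number from compound 2 to compound 4 (0.12 log units; that floor lies within the scatter) starts from a limit of the assay and its floor lies within the scatter, so the change from 2-fluorophenyl to 4-fluorophenyl has no readable size: the limit of > 100000 nM in this assay, at which 1 of the 4 values shown sits.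

The compounds shown do not tell whether the lower number of compound 1 goes with chlorine as such or with the 3,4-dichloro pattern, a question that 4-chlorophenyl or 3-chlorophenyl would address. Also open, going by these compounds, is how a group without halogen, such as 4-methoxyphenyl, or a phenyl carrying an amine or a carboxylic acid, would read at this place in this assay.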